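Compound 3: a ring exchange on compound 2

The compounds below may be only part of what the source reports. "The series", "measured", "known", "first", "only" and "open" are said of these compounds alone.

Measured so far in an ADME assay on a cell-free system (plasma, Mus musculus) for metabolic stability, read by LC-MS, tested at 2 uM; on this read-out lower numbers stand for a shorter-lived compound and higher numbers for a longer-lived compound
Compound 1 `CC(C)CNC(=O)n1c(=O)oc2ccc(C3CCN(C)CC3)cc21` gives 0.5 h
Compound 2 `CN1CCC(c2ccc3c(c2)oc(=O)n3C(=O)NCCCCc2ccccc2)CC1=O` gives 0.6 h

Compound 2 (0.6 h) and compound 1 (0.5 h) lie within the scatter of each other, so neither stands apart on these two numbers. Going by the values given here, no measured pair differs in one place, which leaves no single-change step to read from.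

Compound 3 `CN1CCN(c2ccc3c(c2)oc(=O)n3C(=O)NCCCCc2ccccc2)CC1` carries 4-methylpiperazin-1-yl in place of the 1-methyl-2-oxopiperidin-4-yl of compound 2 on an aromatic carbon (4-methylpiperazin-1-yl in place of 1-methyl-2-oxopiperidin-4-yl on an aromatic carbon). The data hold no measurement of this exchange in this assay. Among the compounds with values here, the only guide is the close agreement of compound 1 (0.5 h) and compound 2 (0.6 h), so no change beyond the scatter is expected, in either direction. The expected step of no change at the digits printed from compound 2 to compound 3 (within the scatter) stays within the scatter. The estimate for compound 3 is 0.6 h (expected range 0.25 h to 1.5 h).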

Compound 3, half-life: < 0.0834 h
Compound 3 was reported as a limit (the forecaster's own chance of this, stated with the estimate: 5%); middle value at least 7.1-fold (0.85 log units) away from the limit.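

In this assay, going by these compounds alone, the first step that changes one place reads an at least 7.1-fold lower number from compound 2 to compound 3 (0.85 log units; beyond the scatter). The substituent on this aromatic carbon can therefore shift the half-life in this assay, and 4-methylpiperazin-1-yl is a clearly less favourable choice here than 1-methyl-2-oxopiperidin-4-yl. The earlier compounds shown here offered no single-place step and so could not show this. The reading for compound 3 is a limit of the assay, not a number: the limit of < 0.0834 h in this assay, at which 1 of the 3 values shown sits.

As far as these compounds go, the exchange alters several features at once, so it remains open whether the step follows the departing ring carbonyl or the entering second ring nitrogen. Also open, from the compounds shown here alone, is how a morpholin-4-yl on the same aromatic carbon, with the rest of compound 2 kept, would read in this assay.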